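Compound 3: a small swap on a benzyl ether chain

The compounds below may be only part of what the source reports. "The series", "measured", "known", "first", "only" and "open" are said of these compounds alone.

Measured in a functional assay on the whole organism with Mus musculus as the target, in the maximal electroshock model; a higher number here means that more compound is needed for the effect, a lower number that less compound is needed:

- Compound 1 `C[C@@H](NCc1ccc(Cc2ccccc2)cc1)C(N)=O`: 22.5 mg/kg
- Compound 2 `C[C@@H](NCc1ccc(OCCc2ccccc2)cc1)C(N)=O`: 12.2 mg/kg

Compound 2 and compound 1 lie within the usual scatter of each other, so these two numbers do not rank them. Compound 3 `C[C@@H](NCc1ccc(OCc2ccc(F)cc2)cc1)C(N)=O` has not been measured yet. It differs from compound 2 in one place (4-fluorophenyl in place of benzyl on a saturated chain carbon bound to an oxygen on an aromatic ring): 4-fluorophenyl in place of benzyl on a saturated chain carbon bound to an oxygen on an aromatic ring.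

Among the compounds with values here, no measured pair differs in just one place, so the data offer no step size to borrow. The expectation therefore rests on compound 2 at 12.2 mg/kg as the nearest measured structure. Expected here is a 1.2-fold lower number from compound 2 to compound 3 (0.09 log units; within the scatter) and so no change beyond the scatter in this assay in either direction. Compound 3 is estimated at 10 mg/kg (expected range 5 mg/kg to 20 mg/kg).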

Compound 3, dose for half-maximal effect: 16.3 mg/kg
Compound 3: middle estimate off by 1.6-fold (0.21 log units), on the low side; the measured number falls inside the stated range.
By their numbers in this assay, from the lowest: compounds 2, 3 and 1 (each within the scatter of the next).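

In this assay, within the data shown here, swapping benzyl for 4-fluorophenyl on a saturated chain carbon bound to an oxygen on an aromatic ring gives a 1.3-fold higher number from compound 2 to compound 3 (0.13 log units; within the scatter) and so provides the first step that can be read at this position. The two groups have the same count of heavy atoms, and each carries one aromatic ring of carbon only, yet this exchange does not move the dose needed beyond the usual scatter. No measurement shown here explains why the two numbers lie so close.

Still open, as far as these compounds go, is whether plain phenyl at this place would behave like 4-fluorophenyl, which would show what the fluorine contributes on its own. Also open, from the compounds shown here alone, is whether an amine, a carboxylic acid or a longer chain here would shift the number beyond the scatter.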